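Trimming the Side Chain: Compound 2 to Compound 3

The compounds below may be only part of what the source reports. "The series", "measured", "known", "first", "only" and "open" are said of these compounds alone.

Within the data shown here, of the two compounds measured so far, compound 2 `CC(C)OC(=O)NCCS(=O)(=O)NC(=O)c1ccc(Nc2nc(NC3(c4ccc(Cl)cc4)CC3)nc(OCC(F)(F)F)n2)cc1` stands lowest: in an ADME assay on microsomes from liver (Rattus norvegicus) for metabolic stability, with a stated time of 10 min (on this read-out higher numbers stand for a more stable compound and lower numbers for a less stable compound), compound 2 gives 73%, whereas compound 1 `CC(C)NCCS(=O)(=O)NC(=O)c1ccc(Nc2nc(NC3(c4ccc(Cl)cc4)CC3)nc(OCC(F)(F)F)n2)cc1` gives 100%. Among the measured compounds shown here, the single measured step, a number 27 percentage points lower from compound 1 to compound 2 (beyond the scatter), touches the same position that changes next. Compound 3 `CC(=O)NCCS(=O)(=O)NC(=O)c1ccc(Nc2nc(NC3(c4ccc(Cl)cc4)CC3)nc(OCC(F)(F)F)n2)cc1` differs from compound 2 by methyl in place of isopropoxy on a carbonyl carbon, which removes part of the group that entered in that step. A partial return toward the value of compound 1 is therefore expected, as a number 12 percentage points higher from compound 2 to compound 3 (beyond the scatter). The estimate for compound 3 is 85%, with a range from 65% to 100%.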

Compound 3, percent of the compound remaining: 100%
Beside the measured number, compound 3's estimate is 15 percentage points below it, and the stated range covers the measured number.
By their numbers in this assay, from the lowest: compound 2; then compounds 1 and 3 (each within the scatter of the next).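

In this assay, methyl in place of isopropoxy on the carbonyl carbon gives a number 27 percentage points higher from compound 2 to compound 3 (beyond the scatter), which matches the size of the earlier drop. Acetyl in place of isopropyl on the amine nitrogen gives no change at the digits printed from compound 1 to compound 3 (within the scatter), so among these three compounds only the isopropoxycarbonyl group goes with the lower number. Nothing given here accounts for this difference.

The compounds shown leave open whether the oxygen or the size of the isopropoxy group matters. Methoxy or a longer chain such as propyl on the same carbonyl carbon could separate the two.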